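Removing the Formyl Group from Compound 1

The source may report more compounds than this note shows. Statements on the series, on what has been measured and on what is new or still open speak of the compounds shown alone.

Among the compounds with values here, in a functional assay on HUVEC cells (Homo sapiens) for antiproliferative activity, read by MTT assay, with a stated time of 24 h (a lower number here means a stronger inhibitor, a higher number a weaker inhibitor), compound 1 `C=CCc1cc(C=O)c(OCC)c(-c2ccc(OCC)c(CC=C)c2)c1` gives 37900 nM and holds the only numeric reading in the set. Compound 2 `C=CCOc1ccc(-c2cccc([N+](=O)[O-])c2)cc1CC=C` gives > 100000 nM which is a limit of the assay and not a number. The step followed here leads to compound 3 `C=CCc1ccc(OCC)c(-c2ccc(OCC)c(CC=C)c2)c1` with hydrogen in place of formyl on an aromatic carbon ortho to an ethoxy group and meta to an allyl group. Within the data shown here, no measured pair shows what such a change does. The expectation therefore rests on compound 1 at 37900 nM alone. In this assay the expected step is a 1.5-fold higher number from compound 1 to compound 3 (0.16 log units; within the scatter) toward slightly weaker inhibition and most likely within the usual scatter. For compound 3 the estimated value is 55000 nM with an expected range from 20000 nM to 100000 nM in the same measurement.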

Compound 3, half-maximal inhibitory concentration: > 100000 nM
Compound 3: a limit, no number (the forecaster's own chance of this, stated with the estimate: 25%); middle value at least 1.8-fold (0.25 log units) from the limit.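

In this assay, the formyl group on this aromatic carbon, ortho to an ethoxy group and meta to an allyl group, proves to count for the reading: hydrogen in its place gives an at least 2.6-fold higher number from compound 1 to compound 3 (0.42 log units; beyond the scatter). Compound 3 reads > 100000 nM, which is a limit of the assay and not a number. The step is therefore only a lower bound, and its full size cannot be read: the limit of > 100000 nM in this assay, at which 2 of the 3 values shown sit.

The compounds shown leave open whether the formyl group itself is needed at this position, or whether a hydroxymethyl group, a carboxylic acid or an amine on the same carbon would also give a measurable number. They also leave open whether the loss of formyl would carry the same weight with other groups in place of the ethoxy or allyl groups.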